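The source may hold more compounds than are shown below. What is called first, only, known or untested is meant among the compounds shown, and "the series" means these compounds.

Among the measured compounds shown here, in a functional assay on L929 cells (Mus musculus) for antiproliferative activity, read by MTT assay (on this read-out higher numbers stand for weaker inhibition and lower numbers for stronger inhibition), compound 1 `C[C@@H]1[C@H]2CC(=O)[C@H](C)[C@H]2C[C@H]1O[Si](c1ccccc1)(c1ccccc1)C(C)(C)C` gives 7400 nM and so sits in the middle of the three compounds measured so far. Compound 2 `C#CC(=O)O[C@H]1C[C@@H]2CC3(C[C@@H]2C1)OCC(C)(C)CO3` gives a lower number at 2200 nM and compound 3 `C=CC[C@@H]1[C@H]2CC(=O)[C@H](C)[C@H]2C[C@H]1O[Si](c1ccccc1)(c1ccccc1)C(C)(C)C` a higher one at 32400 nM on this read-out. Compound 4 `CC(C)=CC[C@H]1C(=O)C[C@@H]2[C@@H](C)[C@H](O[Si](c3ccccc3)(c3ccccc3)C(C)(C)C)C[C@@H]21` keeps the core of compound 1 and differs in one place, with 2-methylprop-1-en-1-yl in place of hydrogen on a saturated chain carbon bound to a saturated ring carbon as the change. Cut one bond further out, methyl becomes 3-methylbut-2-en-1-yl. For the measured compounds named here, only one measured step bears on this. Vinyl in place of hydrogen on a saturated chain carbon bound to a saturated ring carbon gave a 4.4-fold higher number from compound 1 to compound 3 (0.64 log units; beyond the scatter) in a modest move towards weaker inhibition. Going by the values given here, no other measured pair tests a change in this place, so the evidence is thin. Among the compounds with values here, compound 3 at 32400 nM is the only guide, so a step of similar size in the same direction is expected in this assay for the larger group. The estimated move towards weaker inhibition is a 3.4-fold higher number from compound 1 to compound 4 (0.53 log units; beyond the scatter) and carries real uncertainty. For compound 4 the estimate is 25000 nM with an expected range from 9000 nM to 70000 nM.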

Compound 4, half-maximal inhibitory concentration: 23900 nM
For compound 4 the middle estimate is 1.0-fold (0.02 log units) above the measured one; measured number inside the range.
By their numbers in this assay, from the lowest: compound 2; then compound 1; then compounds 4 and 3 (each within the scatter of the next).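

Placing 2-methylprop-1-en-1-yl on this saturated chain carbon gives a 3.2-fold higher number from compound 1 to compound 4 (0.51 log units; beyond the scatter) in this assay, the same direction as the vinyl case, a 4.4-fold higher number from compound 1 to compound 3 (0.64 log units; beyond the scatter), so a second group now points towards weaker inhibition at this position. Compound 3 and compound 4 lie within the usual scatter of each other, which means that the two groups cannot be told apart on this read-out. No measured information explains why either group has this effect.

Going by these compounds, both groups tested here are hydrocarbon chains with a double bond, so it remains open whether a saturated chain such as propyl would give a similar number. An amine or a carboxylic acid in the same place could also behave differently, and the compounds shown give no guide to either.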